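The source may report more compounds than this note shows. Statements on the series, on what has been measured and on what is new or still open speak of the compounds shown alone.

Measured so far:
- compound 1 `COc1ccc(OC)c(-c2cn(-c3ccc(O)c(C(=O)Nc4cccc(C(F)(F)F)c4)c3)nn2)c1`: 46%
- compound 2 `COc1ccc(-c2cn(-c3ccc(O)c(C(=O)O)c3)nn2)cc1`: 8%
- compound 3 `O=C(OCCCc1ccccc1)c1cc(-n2cc(-c3cc(O)ccc3O)nn2)ccc1O`: 39%

Three compounds share a core and were tested in a functional assay on HCT-116 cells (Homo sapiens) for inhibition, read by MTT assay, with a stated time of 2 days, tested at 10 uM; a higher number here means more inhibition at the concentration tested (going by the name of the read-out), a lower number less inhibition. Compound 1 stands highest of the three numbers, but the number of compound 3 lies within the usual scatter of it, so the two cannot be told apart. Compound 2, which carries a free carboxylic acid in place of the amide or ester of the other two, sits far lower than compound 1, a gap well beyond the scatter.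

The next compound, compound 4 `COc1cc(OC)cc(-c2cn(-c3ccc(O)c(C(=O)Nc4cccc(C(F)(F)F)c4)c3)nn2)c1`, has not yet been measured in this assay. It keeps every atom of compound 1 and differs only in how the two methoxy groups are arranged on the phenyl ring attached to the core: 3,5-dimethoxyphenyl in place of 2,5-dimethoxyphenyl on an aromatic carbon.

Within the data shown here, no pair among the measured compounds differs in this way, so there is nothing here that tells how much such a rearrangement changes the read-out. With the rest of the molecule unchanged, the step is expected to be small, in either direction, and most likely within the scatter: a number 4 percentage points lower from compound 1 to compound 4 (within the scatter).

Compound 4 is therefore estimated to give 42% in this assay, with a range from 25% to 58%.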

Compound 4, a percentage reported as inhibition, at one concentration (the size of the read-out at that concentration, not a potency): 62%
Estimate against measurement, compound 4: 20 percentage points below, outside the stated range (above it).
By their numbers in this assay, from the lowest: compound 2; then compounds 3 and 1 (each within the scatter of the next); then compound 4.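

In this assay, among these compounds, 3,5-dimethoxyphenyl in place of 2,5-dimethoxyphenyl gives a number 16 percentage points higher from compound 1 to compound 4 (beyond the scatter), the first step between measured compounds that differ in one place. The two groups have the same heavy atoms, hydrogen-bond donors and acceptors, so this position on the five-membered aromatic ring with 3 nitrogen responds to how the two methoxy groups are arranged on the phenyl ring, even when the group's atoms stay the same. Nothing available here explains why the read-out moves with this rearrangement.

From the compounds shown here alone, this single pair compares only two arrangements of the methoxy groups, so it remains open how the read-out would respond to longer ethoxy groups or to amino groups on the phenyl ring at this position. Going by these compounds, it also remains open whether the same rearrangement would raise the number when the amide of compound 1 is replaced by the ester of compound 3 or by the carboxylic acid of compound 2.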